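The compounds below may be only part of what the source reports. "The series", "measured", "known", "first", "only" and "open" are said of these compounds alone.

Working notes on the series built on the shared core of compound 1 `COc1cc(-c2nn(-c3cccc(NC(=O)c4ccc(Cl)c(C(F)(F)F)c4)c3)cc2-c2ccncc2)ccc1Cl`, all measured in a functional assay on Malme-3M cells (Homo sapiens) for inhibition, read by sulforhodamine B assay, with a stated time of 48 h; a lower number here means that less compound is tolerated, a higher number that more compound is tolerated. In this assay compound 1 gives > 32500 nM, which is a limit of the assay and not a number. Compound 2 `O=C(Nc1cccc(-n2cc(-c3ccncc3)c(-c3ccc(Cl)c(O)c3)n2)c1)Nc1cc(C(F)(F)F)cc(C(F)(F)F)c1` gives 23500 nM in this assay. Compound 3 `COc1cc(-c2nn(-c3cccc(NC(=O)Nc4cccc(C(F)(F)F)c4)c3)cc2-c2ccncc2)ccc1Cl` gives 33900 nM in this assay; compound 3 and compound 2 lie within the scatter of each other, so the two cannot be told apart. For the measured compounds named here, the only measured step touching the group on the carbonyl carbon is a step that the limit leaves unreadable from compound 1 to compound 3, and its size cannot be read because of the limit of > 32500 nM in this assay, at which 1 of the 3 values shown sits. Compound 4 `COc1cc(-c2nn(-c3cccc(NC(=O)c4ccccc4)c3)cc2-c2ccncc2)ccc1Cl` is the next member. It differs from compound 3 as follows: phenyl in place of (3-(trifluoromethyl)phenyl)amino on a carbonyl carbon. Going by the values given here, no measured step gives a size for this exchange, and the two readable numbers, from compound 2 and compound 3, sit close together at the weak end of the range. A shift beyond the scatter is not expected from this change in this assay. The expected step is a 1.0-fold higher number from compound 3 to compound 4 (0.01 log units; within the scatter). Compound 4 is therefore estimated at 35000 nM in this assay, with a range from 15000 nM to 80000 nM, and a fair chance that only a limit is reported.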

Compound 4, concentration lethal to 50% of the cells: > 100000 nM
Compound 4: only a limit was reported; the forecaster's own chance of this, stated with the estimate: 40%; middle value at least 2.8-fold (0.45 log units) away from the limit.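

In this assay, for the compounds shown here, phenyl in place of (3-(trifluoromethyl)phenyl)amino on the carbonyl carbon gives the first readable step at this position, an at least 2.9-fold higher number from compound 3 to compound 4 (0.46 log units; beyond the scatter), so this exchange moves the number beyond the scatter towards more compound tolerated. The value of compound 4, > 100000 nM, is a limit of the assay and not a number, so this step has a lower bound and no measured size. The steps from compound 1 cannot be read, which leaves 4-chloro-3-(trifluoromethyl)phenyl on the carbonyl carbon unplaced against both phenyl and (3-(trifluoromethyl)phenyl)amino: the limit of > 32500 nM in this assay, at which 1 of the 4 values shown sits.

The exchange removes the amino nitrogen and the trifluoromethyl group together, and the compounds shown do not say which of the two carries the step. Phenylamino or 3-(trifluoromethyl)phenyl on the carbonyl carbon would divide the two, while a saturated amine such as piperidine there would show whether an aromatic ring is needed at this position at all.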